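Phenylfuran amides: a chloro for fluoro swap

A few compounds are considered here, and "the series" means these few. Any claim that something is new, unique, unknown or untested is made for them only; others in the source may bear on it.

Measured so far:
compound 1 `Cc1ccccc1N(C)C(=O)c1ccc(-c2cccc(O)c2)o1` gives 29 nM in an assay on T47D cells for inhibition of 17-beta-hydroxysteroid dehydrogenase type 1 (Homo sapiens), read by HPLC, with a stated time of 24 h; a higher number here means a weaker inhibitor, a lower number a stronger inhibitor
compound 2 `Cc1ccccc1N(C)C(=O)c1ccc(-c2ccc(O)c(F)c2)o1` gives 10 nM in this assay

Compound 2 holds the lowest number of the two, with compound 1 the nearest neighbour; the step of a 2.9-fold lower number from compound 1 to compound 2 (0.46 log units; beyond the scatter) is modest but beyond the scatter. Compound 3 `Cc1ccccc1N(C)C(=O)c1ccc(-c2ccc(O)cc2Cl)o1` has not yet been measured. The change is 2-chloro-4-hydroxyphenyl in place of 3-fluoro-4-hydroxyphenyl on an aromatic carbon. Going by the values given here, only the step from compound 1 to compound 2 bears on it, and only loosely: it moved a ring substituent but kept halogen and hydroxyl in one arrangement, whereas here both are repositioned. Nothing in the series shows a chloro group at this place. The expected step in this assay is therefore small, estimated as a 2.0-fold higher number from compound 2 to compound 3 (0.30 log units; within the scatter), in the weaker direction if any. Compound 3 is estimated at 20 nM, range 6 nM to 70 nM.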

Compound 3, half-maximal inhibitory concentration: 14 nM
Estimate against measurement, compound 3: 1.4-fold (0.15 log units) above; the range from low to high includes it.
By their numbers in this assay, from the lowest: compounds 2 and 3 (each within the scatter of the next); then compound 1.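

At this place, next to the ring oxygen, 2-chloro-4-hydroxyphenyl and 3-fluoro-4-hydroxyphenyl cannot be separated in this assay (a 1.4-fold higher number from compound 2 to compound 3 (0.15 log units; within the scatter)). Compared with 3-hydroxyphenyl, the chloro group with its shifted hydroxyl still gives a step beyond the scatter (a 2.1-fold lower number from compound 1 to compound 3 (0.32 log units; beyond the scatter)), so this second halogen pattern is also tolerated. No measurement here offers an explanation for either step.

Open: how 3-chloro-4-hydroxyphenyl would compare, which would separate the halogen from its place, and whether an amine or a carboxylic acid in place of the halogen would hold the number.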